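Saturation at the aromatic carbon: compound 3 pending

This account rests on a few compounds, and the source may have more. Where it says the series, first, only, none or still open, it means among the compounds named here.

Measured so far:
compound 1, `C#Cc1ccc2ccn(CCN3CCCN(C)CC3)c2c1`: 79% in an assay on HEK293 cells for binding affinity to 5-hydroxytryptamine receptor 7 (Homo sapiens), read by radioligand binding, tested at 1 uM; on this read-out higher numbers stand for more inhibition at the one concentration tested (going by the name of the read-out) and lower numbers for less inhibition
compound 2, `CC(C)c1ccc2ccn(CCN3CCCN(C)CC3)c2c1`: 72% in this assay

Compound 2 and compound 1 share the core and differ only in the group on the aromatic carbon of the six-membered ring, isopropyl in place of ethynyl. Compound 2 carries the lower of the two numbers in this assay, but the step of a number 7 percentage points lower from compound 1 to compound 2 (within the scatter) lies within the scatter, so the two cannot be told apart on what is known.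

Compound 3, `C=C(C)c1ccc2ccn(CCN3CCCN(C)CC3)c2c1`, is not yet measured. Its change from compound 2 is 1-methylethenyl in place of isopropyl on an aromatic carbon. Within the data shown here, the single measured step that bears on it is the one from ethynyl to isopropyl, a number 7 percentage points lower from compound 1 to compound 2 (within the scatter), which also exchanged groups of the same size at this carbon and stayed within the scatter. Compound 3 sits between the two in its unsaturation. No step beyond the scatter is therefore expected for compound 3; the estimated step is a number 3 percentage points higher from compound 2 to compound 3 (within the scatter). The value expected for compound 3 in this assay is 75%, with a range from 62% to 88%.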

Compound 3, a percentage reported as inhibition, at one concentration (the size of the read-out at that concentration, not a potency): 72%
The estimate for compound 3 lay 3 percentage points above the measured number, and the stated range covers the measured number.
By their numbers in this assay, from the lowest: compounds 2, 3 and 1 (each within the scatter of the next).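

With 1-methylethenyl in place of isopropyl on the aromatic carbon, this assay gives a direct reading on a double bond outside the aromatic rings in this group (no change at the digits printed from compound 2 to compound 3 (within the scatter)). Against ethynyl, the same group gives (a number 7 percentage points lower from compound 1 to compound 3 (within the scatter)), so this read-out does not separate ethynyl, isopropyl and 1-methylethenyl at this carbon, and the three compounds give no trend with unsaturation. No measurement in hand explains why these groups read alike.

All three groups contain only carbon and hydrogen, so it remains open whether an amine, a carboxylic acid, a nitrile or a longer chain at this carbon would stay within the scatter of these compounds. Going by these compounds, a reading of inhibition at one concentration gives only the size of the effect at that concentration, so how compound 1, compound 2 and compound 3 would compare at other concentrations remains open as well.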